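This account rests on a few compounds, and the source may have more. Where it says the series, first, only, none or still open, it means among the compounds named here.

Of the compounds shown here, three have so far been tested in an assay on isolated protein for inhibition of ribosomal protein S6 kinase beta-1 (Homo sapiens), read by HTRF, tested at 10 uM; on this read-out higher numbers stand for more inhibition at the one concentration tested (going by the name of the read-out) and lower numbers for less inhibition. Compound 2, with the structure `Clc1ccc2sc(CN3CCN(c4ncnc5c4CN(Cc4ccccc4)CC5)CC3)cc2c1`, gives 11% in this assay, the highest of the three numbers, although both of its neighbours sit within the usual scatter of it. Compound 1, `Cc1cccc(Oc2ccnc(N3CCC[C@H]3C(=O)NCCCn3ccnc3)n2)c1`, gives 7%, and compound 3, `Cc1cccc(Nc2nccc3c2CN(C(=O)c2cc(C)n(C)c2C)CC3)c1`, gives 6%. All three numbers are small, so none of these compounds does much to the enzyme at the one concentration tested, and no ordering among them can be claimed.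

Compound 4, `O=C(CN1CCN(c2ncnc3c2CN(Cc2ccccc2)CC3)CC1)Nc1cc(F)ccc1F`, has not yet been measured in this assay. It is built from compound 2 by a single change: (2,5-difluorophenyl)carbamoyl in place of 5-chloro-1-benzothiophen-2-yl on a saturated chain carbon bound to an amine nitrogen in a ring. The part that leaves carries two fused rings and no hydrogen-bond donor; the part that enters carries one ring, an amide with one hydrogen-bond donor, and two fluorine atoms. Within the data shown here, no pair of measured compounds differing in one place is available to show how this assay responds to such a swap, so the expectation rests on the weak numbers of all three measured compounds.

On that basis the step of a number 1 percentage points lower from compound 2 to compound 4 (within the scatter) is expected to stay within the scatter, with no clear movement in either direction. Compound 4 is therefore estimated to give about 10% in this assay, most likely between 0% and 25%.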

Compound 4, a percentage reported as inhibition, at one concentration (the size of the read-out at that concentration, not a potency): 8%
For compound 4 the middle estimate is 2 percentage points above the measured one, within the range that was stated.
By their numbers in this assay, from the lowest: compounds 3, 1, 4 and 2 (each within the scatter of the next).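

In this assay, putting (2,5-difluorophenyl)carbamoyl in place of 5-chloro-1-benzothiophen-2-yl on a saturated chain carbon bound to an amine nitrogen in a ring gives a number 3 percentage points lower from compound 2 to compound 4 (within the scatter). Among these compounds, this is the first pair in the set that differs in only one place, and it shows that two fused aromatic rings without a hydrogen-bond donor and a single aromatic ring carrying an amide, a hydrogen-bond donor and two fluorine atoms cannot be told apart at this position, with inhibition remaining small on both sides. No measurement shown here explains why the two compounds cannot be separated.

On these data alone, it remains open whether a different group on this chain carbon, such as a carboxylic acid or a simple amine, would move the number beyond the usual scatter. Among the compounds shown here, also unresolved is whether any change to the shared core would raise inhibition, and a reading at one concentration gives no potency for comparing compounds that all sit this low.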